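From Ethoxycarbonyl to Thiophen-2-yl on the Amide Carbon

The source may report more compounds than this note shows. Statements on the series, on what has been measured and on what is new or still open speak of the compounds shown alone.

Three compounds built on one shared core have been measured in a functional assay on SiHa cells (Homo sapiens) for inhibition; on this read-out higher numbers stand for weaker inhibition and lower numbers for stronger inhibition:

compound 1 `COc1cc(/C=C/C(=O)c2cccc(NC(=O)c3ccc(Cl)c(Cl)c3)c2)ccc1O` gives 25.3 ug/mL;
compound 2 `COC(=O)C(=O)Nc1cccc(C(=O)/C=C/c2ccc(O)c(OC)c2)c1` gives 7.71 ug/mL;
compound 3 `CCOC(=O)C(=O)Nc1cccc(C(=O)/C=C/c2ccc(O)c(OC)c2)c1` gives > 50 ug/mL.

The value of compound 3 is a limit of this assay, not a number, so compound 3 stands only as a floor and its true inhibition is not pinned down. Compound 1 and compound 2 both sit inside the measurable range, and between them the move was a 3.3-fold lower number from compound 1 to compound 2 (0.52 log units; beyond the scatter). Lengthening the ester of compound 2 gave an at least 6.4-fold higher number from compound 2 to compound 3 (0.81 log units; beyond the scatter), while from compound 1 the move was an at least 1.9-fold higher number from compound 1 to compound 3 (0.29 log units; that floor lies within the scatter).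

Compound 4 `COc1cc(/C=C/C(=O)c2cccc(NC(=O)c3cccs3)c2)ccc1O` has not yet been measured. Its change from compound 3 is thiophen-2-yl in place of ethoxycarbonyl on a carbonyl carbon. Within the data shown here, no measured step matches this exactly; the nearest relation is the move from compound 1 to compound 3, which put ethoxycarbonyl in place of 3,4-dichlorophenyl on that same carbonyl carbon, and compound 4 reverses that kind of swap by restoring an aromatic group, thiophen-2-yl. A return toward the number of compound 1 is therefore expected, giving an estimated step of an at least 2.5-fold lower number from compound 3 to compound 4 (0.39 log units; beyond the scatter). Compound 4 is thus expected to come in near 20 ug/mL, within roughly 6 ug/mL to 50 ug/mL.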

Compound 4, half-maximal inhibitory concentration: 6.57 ug/mL
For compound 4 the middle estimate is 3.0-fold (0.48 log units) above the measured one; low and high end bracket the measured number.
By their numbers in this assay, from the lowest: compounds 4 and 2 (each within the scatter of the next); then compound 1. At a limit, above all of these: compound 3.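

In this assay, putting thiophen-2-yl in place of ethoxycarbonyl on the carbonyl carbon gave an at least 7.6-fold lower number from compound 3 to compound 4 (0.88 log units; beyond the scatter), and that size is only a floor, for the value of compound 3 is a limit and not a number: the limit of > 50 ug/mL in this assay, at which 1 of the 4 values shown sits.

The same swap against the smaller ester gave a 1.2-fold lower number from compound 2 to compound 4 (0.07 log units; within the scatter), so at this place a five-membered aromatic ring and methoxycarbonyl cannot be told apart on this read-out, although the two groups have little else in common. Thiophen-2-yl in place of the other aromatic group gave a 3.9-fold lower number from compound 1 to compound 4 (0.59 log units; beyond the scatter), which shows that carrying an aromatic ring on this carbonyl carbon does not by itself set the number, since the choice of ring matters as well.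

The compounds shown leave open whether the sulfur of the thiophene counts or only the size of the ring, a question that furan-2-yl or an unsubstituted phenyl on the same carbonyl carbon could answer. They also leave open how a carboxylic acid in place of the ester would read, next to methoxycarbonyl and ethoxycarbonyl.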